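From compound 2 to compound 4: adding one methoxy

This account rests on a few compounds, and the source may have more. Where it says the series, first, only, none or still open, it means among the compounds named here.

compound 1 `O=C(/C=C\Nc1ccc(Cl)cc1)c1cn(-c2ccccc2)nc1-c1ccccc1`: 3610 nM
compound 2 `O=C(/C=C\Nc1ccc(C(F)(F)F)cc1)c1cn(-c2ccccc2)nc1-c1ccccc1`: > 50000 nM (a limit)
compound 3 `O=C(/C=C\Nc1ccc(O)cc1)c1cn(-c2ccccc2)nc1-c1ccccc1`: 5000 nM

In a functional assay on HT-29 cells (Homo sapiens) for antiproliferative activity, read by MTT assay, with a stated time of 48 h (on this read-out lower numbers stand for stronger inhibition and higher numbers for weaker inhibition), compound 2 stands at > 50000 nM and this is a limit of the assay, not a number. Compound 4 `COc1ccc(-c2nn(-c3ccccc3)cc2C(=O)/C=C\Nc2ccc(C(F)(F)F)cc2)cc1` differs from compound 2 by one change, methoxy in place of hydrogen on an aromatic carbon (phenyl to 4-methoxyphenyl). Among the measured compounds shown here, no measured step touches that place. The measured steps swap chloro, trifluoromethyl and hydroxy at another position, and they bear only indirectly: single swaps gave an at least 13-fold higher number from compound 1 to compound 2 (1.14 log units; beyond the scatter) and an at least 10-fold lower number from compound 2 to compound 3 (1.00 log units; beyond the scatter), whereas a 1.4-fold higher number from compound 1 to compound 3 (0.14 log units; within the scatter) stayed small. The trifluoromethyl group of compound 2 remains in compound 4, so no step beyond the scatter is expected in this assay. The expected change is an at least 1.2-fold lower number from compound 2 to compound 4 (0.09 log units; that floor lies within the scatter) (an estimate). For compound 4 the estimated value is 40000 nM (expected range 8000 nM to 100000 nM).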

Compound 4, half-maximal inhibitory concentration: 9870 nM
Beside the measured number, compound 4's estimate is 4.1-fold (0.61 log units) above it; measured number inside the range.
By their numbers in this assay, from the lowest: compounds 1, 3 and 4 (each within the scatter of the next, the first and the last beyond it). At a limit, above all of these: compound 2.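

In this assay, among the compounds shown here, the change from phenyl to 4-methoxyphenyl gives an at least 5.0-fold lower number from compound 2 to compound 4 (0.70 log units; beyond the scatter) and so shows that this position, the same in all the earlier compounds, can shift the number beyond the scatter while trifluoromethyl stays in place. The full size of this step cannot be read, because compound 2 carries a limit and not a number: the limit of > 50000 nM in this assay, at which 1 of the 4 values shown sits.

From the compounds shown here alone, what an amine or a carboxylic acid would do at this position stays open. So does whether methoxy would have a similar effect with the chloro of compound 1 or the hydroxy of compound 3 in place of trifluoromethyl.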